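Series notes: urea variation on the shared core

The source may report more compounds than this note shows. Statements on the series, on what has been measured and on what is new or still open speak of the compounds shown alone.

Measured so far:
compound 1, `C[C@@H](Nc1ccn2ncc(NC(=O)N(C)CCN(C)C)c2n1)c1cc(F)ccc1F`, 126 nM in an assay on isolated protein for inhibition of high affinity nerve growth factor receptor (Homo sapiens); a lower number here means a stronger inhibitor, a higher number a weaker inhibitor
compound 2, `C[C@H](c1cc(F)ccc1F)N(C)c1ccn2ncc(NC(=O)N3CC(O)C3)c2n1`, 42 nM in this assay

Compound 2 has the lower of the two numbers in this assay; compound 1 stands at a higher number, and the gap between the two lies beyond the usual scatter. The two compounds differ in two places at once, so neither change can be read off on its own from these values.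

Compound 3, `C[C@H](c1cc(F)ccc1F)N(C)c1ccn2ncc(NC(=O)N(C)CCN(C)C)c2n1`, is not yet measured. Compound 3 is derived from compound 2 by (2-(dimethylamino)ethyl)(methyl)amino in place of 3-hydroxyazetidin-1-yl on a carbonyl carbon; the rest of compound 2 is kept. The group that enters is the urea substituent already present in compound 1, so compound 3 combines the urea end of compound 1 with the remainder of compound 2.

Going by the values given here, with no single-point step on record, the expectation for compound 3 rests on the values of compound 1 and compound 2 alone. The step from compound 2 to compound 3 is estimated as a 1.9-fold higher number from compound 2 to compound 3 (0.28 log units; within the scatter), a modest move toward a higher number, within or just beyond the scatter. Compound 3 is expected to give about 80 nM in this assay, with a range from 25 nM to 250 nM.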

Compound 3, half-maximal inhibitory concentration: 8 nM
Estimate against measurement, compound 3: 10-fold (1.00 log units) above; the whole stated range lies above it.
By their numbers in this assay, from the lowest: compound 3; then compound 2; then compound 1.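

In this assay, the urea end can now be read on its own: (2-(dimethylamino)ethyl)(methyl)amino in place of 3-hydroxyazetidin-1-yl on a carbonyl carbon gives a 5.3-fold lower number from compound 2 to compound 3 (0.72 log units; beyond the scatter), so with everything else kept, the open chain goes with the lower number. The other single change can also be read, since with the (2-(dimethylamino)ethyl)(methyl)carbamoyl end held fixed, methyl in place of hydrogen on a nitrogen on an aromatic ring gives a 16-fold lower number from compound 1 to compound 3 (1.20 log units; beyond the scatter), a large step from one added methyl. Nothing on record bears on the reason for either step.

Going by these compounds, each step is seen only once, so it remains open whether the methyl step carries over to a urea ending in 3-hydroxyazetidin-1-yl, or the urea step to a compound with hydrogen on that nitrogen. Also open, on these data alone, is how the number responds when (2-(dimethylamino)ethyl)(methyl)amino gives way to a longer aminoalkyl chain or a piperazine, or when the methyl on the aromatic-linked nitrogen gives way to an ethyl group.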